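The source may report more compounds than this note shows. Statements on the series, on what has been measured and on what is new or still open speak of the compounds shown alone.

Compound 1 (`C=CCNC(=C\C(=O)/C=C/c1ccc(O)c(OC)c1)/C=C/c1ccc(O)c(OC)c1`) in an ADME assay on EA.hy 926 cells (Homo sapiens) for inhibition, read by sulforhodamine B assay, with a stated time of 72 h (a lower number here means a stronger inhibitor, a higher number a weaker inhibitor), gives > 25000 nM as a limit of the assay and not a number. Compound 2 (`CCC(C)NC(=C\C(=O)/C=C/c1ccc(O)cc1)/C=C/c1ccc(O)cc1`) gives > 25000 nM as a limit too. Compound 1 thus stands with compound 2 at the limit of > 25000 nM in this assay, at which 2 of the 2 values shown sit, and has no number yet. Compound 3 (`CCCCNC(=C\C(=O)/C=C/c1ccc(O)c(OC)c1)/C=C/c1ccc(O)c(OC)c1`) carries butylamino for allylamino, propyl in place of vinyl on a saturated chain carbon bound to an amine nitrogen. No measured step sizes this change, so none beyond the scatter is expected in this assay in either direction. The estimated a number no higher from compound 1 to compound 3 (the limit leaves the size open) is accordingly small. Compound 3 is expected at 25000 nM with an estimated range from 10000 nM to 50000 nM and may return only a limit.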

Compound 3, half-maximal inhibitory concentration: > 25000 nM
Compound 3: a limit, no number (the forecaster's own chance of this, stated with the estimate: 65%); the middle value sits exactly at the limit.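

No step can be read between compound 1 and compound 3, since each gives only a limit and not a number in this assay. The compounds shown leave open how the amine substituent affects inhibition, with all of them at one limit: the limit of > 25000 nM in this assay, at which 3 of the 3 values shown sit.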